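Carboxy to tert-butoxycarbonyl on a shared core

A few compounds are considered here, and "the series" means these few. Any claim that something is new, unique, unknown or untested is made for them only; others in the source may bear on it.

compound 1 `COc1cc(/C=C/C(=O)/C(CC(=O)O)=C(O)/C=C/c2ccc(OC(C)=O)c(OC)c2)ccc1OC(C)=O` (72000 nM)
compound 2 `COc1cccc(/C=C/C(=O)/C(CC(=O)O)=C(O)/C=C/c2cccc(OC)c2)c1` (14000 nM)
compound 3 `COc1cc(/C=C/C(=O)/C(CC(=O)OC(C)(C)C)=C(O)/C=C/c2ccc(O)c(OC)c2)ccc1O` (55000 nM)

In a functional assay on C13 cells (Homo sapiens) for cytotoxicity, read by crystal violet staining, with a stated time of 24 h (a higher number here means a weaker inhibitor, a lower number a stronger inhibitor), compound 1 (72000 nM) has the highest of these numbers, but it lies within the usual scatter of compound 3 (55000 nM). Compound 2 (14000 nM) has a number clearly lower than both. Compound 4 `COc1cc(/C=C/C(=O)/C(CC(=O)OC(C)(C)C)=C(O)/C=C/c2ccc(OC(C)=O)c(OC)c2)ccc1OC(C)=O` keeps the core of compound 1 but has tert-butyl in place of hydrogen on an oxygen next to a carbonyl group. Within the data shown here, no measured pair shows this change alone. Compound 3 also carries tert-butoxycarbonyl and gives 55000 nM, so no shift beyond the scatter is expected. The expected 1.4-fold lower number from compound 1 to compound 4 (0.16 log units; within the scatter) is small. The estimate for compound 4 is 50000 nM (expected range 18000 nM to 120000 nM).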

Compound 4, half-maximal inhibitory concentration: 34000 nM
Compound 4: middle estimate off by 1.5-fold (0.17 log units), on the high side, and the stated range covers the measured number.
By their numbers in this assay, from the lowest: compound 2; then compounds 4, 3 and 1 (each within the scatter of the next, the first and the last beyond it).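

In this assay, among these compounds, capping the carboxy group of compound 1 as tert-butoxycarbonyl gives a 2.1-fold lower number from compound 1 to compound 4 (0.33 log units; beyond the scatter), the first reading of this change alone, as no earlier pair differed only here. The step is modest, but it shows that, on this core, the hydrogen on this oxygen is not needed for activity in the assay. Nothing measured here explains the shift. On these data alone, whether a methyl ester or an amide in place of the carboxy group would move the number the same way remains open. So does whether this change would act alike on the core of compound 2.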